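Adding a Methoxy Group: Expected Effect on Growth Inhibition

This account rests on a few compounds, and the source may have more. Where it says the series, first, only, none or still open, it means among the compounds named here.

Compound 1 `COc1c(/C=C2/C(=O)Nc3ccccc32)c2ccccc2n1-c1ccccc1`: 1230 nM
Compound 2 `O=C1Nc2ccc(Cl)cc2/C1=C\c1c(Cl)n(CCCc2ccccc2)c2ccccc12`: 2190 nM

In a functional assay on cells (Cancer cell lines, Homo sapiens) for cytotoxicity, with a stated time of 48 h (on this read-out lower numbers stand for stronger inhibition of growth and higher numbers for weaker inhibition of growth), compound 1 gives 1230 nM and compound 2 gives 2190 nM; the gap between them lies within the usual scatter of the method, so the two cannot be told apart. Compound 3 `COc1ccc2c(c1)/C(=C\c1c(OC)n(-c3ccccc3)c3ccccc13)C(=O)N2` differs from compound 1 by methoxy in place of hydrogen on an aromatic carbon. Among the measured compounds shown here, no measured pair shows this change on its own, so its effect is not known from the data; a small step in this assay is expected, in either direction or none beyond the scatter. Compound 3 is therefore estimated at 1100 nM, with a range from 400 nM to 3000 nM. The expected step of a 1.1-fold lower number from compound 1 to compound 3 (0.05 log units; within the scatter) is small.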

Compound 3, concentration for 50% growth inhibition: 630 nM
For compound 3 the middle estimate is 1.7-fold (0.24 log units) above the measured one; low and high end bracket the measured number.
By their numbers in this assay, from the lowest: compounds 3, 1 and 2 (each within the scatter of the next, the first and the last beyond it).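

In this assay, methoxy in place of hydrogen on this aromatic carbon, meta to a fused ring and para to a fused ring, gives a 2.0-fold lower number from compound 1 to compound 3 (0.29 log units; within the scatter). Among the compounds shown here, this is the first direct reading at this position: on the core of compound 1 it accepts methoxy, and compound 1 and compound 3 cannot be told apart. Nothing measured here gives a reason for this step. Still open, as far as these compounds go, is whether a larger or different group at this position, such as an amine or a carboxylic acid, would leave the number within the scatter too.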